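A few compounds are considered here, and "the series" means these few. Any claim that something is new, unique, unknown or untested is made for them only; others in the source may bear on it.

For the measured compounds named here, in an assay on C3H 10T1/2 cells for inhibition of Sonic hedgehog protein (Mus musculus), read by a luciferase reporter (on this read-out lower numbers stand for stronger inhibition and higher numbers for weaker inhibition), compound 3 `Cc1nc(C(F)(F)F)ccc1C(=O)Nc1ccc(Cl)c(-c2cnccn2)c1` gives 1700 nM, the highest number of the three compounds measured so far; its nearest neighbour is compound 2 `Cc1nc(C(F)(F)F)ccc1C(=O)Nc1ccc(Cl)c(-n2cccn2)c1`, which gives 450 nM, and furthest from it is compound 1 `Cc1nc(C(F)(F)F)ccc1C(=O)Nc1ccc(Cl)c(-c2cn3ccsc3n2)c1`, which gives 200 nM. Compound 4 `Cc1nc(C(F)(F)F)ccc1C(=O)Nc1ccc(Cl)c(-c2cnc3ccccc3n2)c1` differs from compound 3 by quinoxalin-2-yl in place of pyrazin-2-yl on an aromatic carbon: the single ring grows into a fused pair of rings. Going by the values given here, the steps that bear on this are an 8.5-fold higher number from compound 1 to compound 3 (0.93 log units; beyond the scatter) and a 2.3-fold higher number from compound 1 to compound 2 (0.35 log units; beyond the scatter), where compound 1 carries a fused pair of rings at the same position and gives the lowest number, while the shift a 3.8-fold higher number from compound 2 to compound 3 (0.58 log units; beyond the scatter) shows that the six-membered ring alone sits at the weak end. Since a two-ring group at this position has so far gone with the strongest inhibition in this assay, compound 4 is expected to move back toward compound 1, and the step of a 3.4-fold lower number from compound 3 to compound 4 (0.53 log units; beyond the scatter) is estimated as a lower number. Compound 4 is therefore expected to give about 500 nM, within a range from 150 nM to 1700 nM.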

Compound 4, half-maximal inhibitory concentration: 52 nM
Estimate against measurement, compound 4: 9.6-fold (0.98 log units) above; the whole stated range lies above it.
By their numbers in this assay, from the lowest: compound 4; then compound 1; then compound 2; then compound 3.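

In this assay, fusing a six-membered aromatic ring of carbon only onto pyrazin-2-yl brings a 33-fold lower number from compound 3 to compound 4 (1.51 log units; beyond the scatter) and is the largest step yet seen at this position on the aromatic carbon, so adding a second ring can outweigh the choice of single ring. Two-ring groups are not interchangeable here, for quinoxalin-2-yl also gives a 3.8-fold lower number from compound 1 to compound 4 (0.59 log units; beyond the scatter) when it replaces the fused pair of five-membered rings, and it surpasses the single five-membered ring with an 8.7-fold lower number from compound 2 to compound 4 (0.94 log units; beyond the scatter) as well. Nothing available explains why the larger group gives the lowest number.

Going by these compounds, whether the two ring nitrogens of quinoxalin-2-yl matter remains open, and naphthalen-2-yl, with carbon only in both rings, would address that. Also open, on these data alone, is whether a methoxy group or an amine on the added ring would keep the number this low.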